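The source may hold more compounds than are shown below. What is called first, only, known or untested is meant among the compounds shown, and "the series" means these compounds.

The measured compounds and their numbers:

compound 1 `CN(C)c1nc(N)sc1C(=O)c1cnc2ccccn12` gives 32%
compound 2 `Cc1ccn2c(C(=O)c3sc(N)nc3N(C)C)cnc2c1` gives 85%
compound 3 `Nc1nc(-c2ccccc2)c(C(=O)c2cnc3ccccn23)s1` gives 40%

In a functional assay on the whole organism (strain Sprague-Dawley) for inhibition, with Rattus norvegicus as the target, read by paw edema, with stated times of 1 h and 3 h, at a dose of 50 mg/kg by the oral route (a lower number here means less inhibition, a higher number more inhibition at the dose given (going by the name of the read-out)), compound 3 stands second highest of the three. Its nearest neighbour is compound 1, and the step of a number 8 percentage points higher from compound 1 to compound 3 (within the scatter) lies within the scatter, so the two cannot be ordered. Compound 2 stands furthest away, its number being beyond the scatter above that of compound 3.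

Compound 4 `Cc1ccn2c(C(=O)c3sc(N)nc3-c3ccccc3)cnc2c1` differs from compound 3 in one place: methyl in place of hydrogen on an aromatic carbon

Going by the values given here, one measured step bears directly on this change. The step of a number 53 percentage points higher from compound 1 to compound 2 (beyond the scatter) is the same exchange of methyl for hydrogen on the same aromatic carbon of the shared core, and it was large and well beyond the scatter. Among the compounds with values here, no step of this kind is available starting from the phenyl-bearing series, and the change from dimethylamino to phenyl itself left the number within the scatter. A large upward step is therefore expected, estimated as a number 40 percentage points higher from compound 3 to compound 4 (beyond the scatter). Compound 4 is expected to give about 80%, with an estimated range from 55% to 98%.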

Compound 4, a percentage reported as inhibition, in the whole organism at one dose (the size of the read-out at that dose, not a potency): 26%
Beside the measured number, compound 4's estimate is 54 percentage points above it; measured number below the stated range.
By their numbers in this assay, from the lowest: compounds 4, 1 and 3 (each within the scatter of the next, the first and the last beyond it); then compound 2.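

In this assay, methyl in place of hydrogen on an aromatic carbon, opposite the ring nitrogen, does not push the number in one fixed direction: with phenyl on the shared core, the exchange gives a number 14 percentage points lower from compound 3 to compound 4 (beyond the scatter), so its outcome depends on the group present elsewhere in the molecule: the same change on two cores in this assay, a number 53 percentage points higher (beyond the scatter) from compound 1 to compound 2 and a number 14 percentage points lower (beyond the scatter) from compound 3 to compound 4, 67 percentage points apart, beyond the scatter of two such steps

Read the other way, phenyl in place of dimethylamino had made no difference beyond the scatter without the methyl, but with the methyl present it gives a number 59 percentage points lower from compound 2 to compound 4 (beyond the scatter), so this exchange depends on the methyl in turn: the same change on two cores in this assay, a number 8 percentage points higher (within the scatter) from compound 1 to compound 3 and a number 59 percentage points lower (beyond the scatter) from compound 2 to compound 4, 67 percentage points apart, beyond the scatter of two such steps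

The two changes therefore do not add up across these four compounds, and the high number of compound 2, 85%, belongs to the pairing of methyl with dimethylamino and not to the methyl alone.

As far as these compounds go, whether that pairing needs dimethylamino in particular, or would also hold with a cyclic amine such as morpholine or with a small alkyl group such as ethyl, stays open. So does whether a methoxy or a chlorine on the same aromatic carbon would behave as the methyl does.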